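Anilide variation on a shared triazole-dioxolane core

This account rests on a few compounds, and the source may have more. Where it says the series, first, only, none or still open, it means among the compounds named here.

Compound 1 `CCCC(=O)Nc1ccc(N2CCN(c3ccc(OC[C@@H]4CO[C@@](Cn5cncn5)(c5ccc(Cl)cc5Cl)O4)cc3)CC2)cc1` and compound 2 `O=C(CCCCc1ccccc1)Nc1ccc(N2CCN(c3ccc(OC[C@@H]4CO[C@@](Cn5cncn5)(c5ccc(Cl)cc5Cl)O4)cc3)CC2)cc1` share the whole core and differ only in the amide acyl group. In a functional assay on A549 cells (Homo sapiens) for inhibition, read by MTT assay, with a stated time of 48 h (on this read-out lower numbers stand for stronger inhibition and higher numbers for weaker inhibition), compound 1 gives 2990 nM, and compound 2 gives 2610 nM. The one measured step, a 1.1-fold lower number from compound 1 to compound 2 (0.06 log units; within the scatter), is within the scatter, so the two numbers shown cannot be ordered; compound 2 simply sits at the same level as compound 1.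

Compound 3 `O=C(Nc1ccc(N2CCN(c3ccc(OC[C@@H]4CO[C@@](Cn5cncn5)(c5ccc(Cl)cc5Cl)O4)cc3)CC2)cc1)c1ccc(F)c(F)c1` carries the change (3,4-difluorophenyl in place of 4-phenylbutyl on a carbonyl carbon). Going by the values given here, the only step available, a 1.1-fold lower number from compound 1 to compound 2 (0.06 log units; within the scatter), concerns growth at the far end of the chain rather than exchange of the whole group on the carbonyl carbon, so it bears on compound 3 only loosely; it does show that altering the acyl group moved nothing beyond the scatter. On that basis compound 3 is expected to give 2700 nM, with a range of 1200 nM to 6500 nM, meaning an expected step of a 1.0-fold higher number from compound 2 to compound 3 (0.01 log units; within the scatter) of no size beyond the scatter.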

Compound 3, half-maximal inhibitory concentration: 8690 nM
Compound 3: middle estimate off by 3.2-fold (0.51 log units), on the low side; measured number outside the range, above it.
By their numbers in this assay, from the lowest: compounds 2 and 1 (each within the scatter of the next); then compound 3.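

In this assay the group on the carbonyl carbon does register: 3,4-difluorophenyl in place of 4-phenylbutyl gives a 3.3-fold higher number from compound 2 to compound 3 (0.52 log units; beyond the scatter), and 3,4-difluorophenyl in place of propyl gives a 2.9-fold higher number from compound 1 to compound 3 (0.46 log units; beyond the scatter). Both steps are modest but beyond the scatter and run the same way, so the level shared by the propyl and 4-phenylbutyl amides does not carry over to 3,4-difluorophenyl. No measurement at hand gives a cause for this weaker inhibition.

Still open, from the compounds shown here alone, is whether the higher number goes with the two fluorines or with the aromatic ring standing directly on the carbonyl carbon; an unsubstituted phenyl at this place would separate the two. A benzyl or 2-phenylethyl group on the carbonyl carbon would show how much chain the aromatic ring needs for the level of compound 2 to return.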